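The source may report more compounds than this note shows. Statements on the series, on what has been measured and on what is new or still open speak of the compounds shown alone.

Among the compounds with values here, in an ADME assay on microsomes from liver (Homo sapiens) for metabolic stability (a higher number here means that the compound lasts longer, a lower number that the compound disappears faster), compound 2 `CC#C[C@@H](Cc1nnn[nH]1)c1ccc(OCc2ccc3scc(-c4cc(OCCOC)ccc4C)c3c2)cc1` gives 0.867 h, the only true number so far. Compound 1 `CC#C[C@@H](Cc1nnn[nH]1)c1ccc(OCc2ccc3scc(-c4cccnc4C)c3c2)cc1` gives < 0.0667 h, which is a limit of the assay and not a number.

Compound 3 `CC#C[C@@H](Cc1nnn[nH]1)c1ccc(OCc2ccc3scc(C4CCCCC4)c3c2)cc1` carries cyclohexyl in place of 5-(2-methoxyethoxy)-2-methylphenyl on an aromatic carbon of a five-membered aromatic ring with 1 sulfur: cyclohexyl in place of 5-(2-methoxyethoxy)-2-methylphenyl on an aromatic carbon.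

Within the data shown here, one measured step bears on this carbon: an at least 12-fold higher number from compound 1 to compound 2 (1.11 log units; beyond the scatter), large and beyond the scatter, with 5-(2-methoxyethoxy)-2-methylphenyl entering in place of 2-methylpyridin-3-yl. With a single step as the guide, the group now leaving is the one that gave the higher number, so a fall in this assay is expected, though a smaller one than that step. The expected step is a 2.9-fold lower number from compound 2 to compound 3 (0.46 log units; beyond the scatter). Compound 3 is estimated at 0.3 h, with an expected range of 0.08 h to 1 h.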

Compound 3, half-life: 0.183 h
Beside the measured number, compound 3's estimate is 1.6-fold (0.21 log units) above it; the measured number falls inside the stated range.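

Cyclohexyl on this aromatic carbon gives a 4.7-fold lower number from compound 2 to compound 3 (0.68 log units; beyond the scatter) in this assay, so a non-aromatic ring of carbon only does not match 5-(2-methoxyethoxy)-2-methylphenyl here. The same group gives an at least 2.7-fold higher number from compound 1 to compound 3 (0.43 log units; beyond the scatter), which shows that a higher number at this carbon does not depend on 5-(2-methoxyethoxy)-2-methylphenyl alone and places three groups in an order, with cyclohexyl in the middle. Compound 1 remains a limit and not a number, so this second step sets only a floor on the difference: the limit of < 0.0667 h in this assay, at which 1 of the 3 values shown sits.

Still open, on these data alone, is how much of the higher number of compound 2 belongs to the 2-methoxyethoxy chain and how much to the aromatic ring that carries it. A plain 2-methylphenyl, or a cyclohexyl carrying a 2-methoxyethoxy chain or an amine, would separate the two.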